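Working notes on the series: cytotoxicity limits and compound 4

The source may report more compounds than this note shows. Statements on the series, on what has been measured and on what is new or still open speak of the compounds shown alone.

compound 1 `CC(=O)Nc1cccc(-c2ccc(C(=O)N(Cc3cccc(OCCCCCC(=O)O)c3)C(C)C)cc2)c1`: > 26000 nM
compound 2 `CC(C)N(Cc1cccc(OCCCCCC(=O)O)c1)C(=O)c1ccc(-c2cccc(-c3ccccc3)c2)cc1`: > 26000 nM
compound 3 `CC(C)Oc1cccc(-c2ccc(C(=O)N(Cc3cccc(OCCCCCC(=O)O)c3)C(C)C)cc2)c1`: > 26000 nM

In an ADME assay on BJ cells (Homo sapiens) for cytotoxicity, read by CellTiter-Glo and resazurin assay, with a stated time of 72 h (a lower number here means that less compound is needed, a higher number that more compound is needed for the effect), compound 1 gives > 26000 nM, which is a limit of the assay and not a number. Compound 2 likewise stands at a limit, > 26000 nM. Compound 3 stands at a limit as well, > 26000 nM. All three readings sit on the same limit (the limit of > 26000 nM in this assay, at which 3 of the 3 values shown sit), so compound 1 cannot be placed relative to the other two, and the steps a step that the two limits leave unreadable from compound 1 to compound 2, a step that the two limits leave unreadable from compound 1 to compound 3 and a step that the two limits leave unreadable from compound 2 to compound 3 are unreadable for the same reason.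

Compound 4 `CC(C)N(Cc1cccc(OCCCCCC(=O)O)c1)C(=O)c1ccc(-c2c[nH]c3ccccc23)cc1` is not yet measured. It differs from compound 1 in one place: 1H-indol-3-yl in place of 3-acetamidophenyl on an aromatic carbon. Going by the values given here, none of the measured steps reads to a size, so none gives a direction; together they show only that acetamido, phenyl and isopropoxy at this position have all left the compound at the limit. The expectation for compound 4 is therefore that it also stays at or near the limit, with a number no higher from compound 1 to compound 4 (the limit leaves the size open) expected to be no step beyond the scatter. Compound 4 is estimated at 26000 nM, in the range 10000 nM to 80000 nM.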

Compound 4, half-maximal effective concentration: > 26000 nM
Compound 4 ended at the assay's limit; the forecaster's own chance of this, stated with the estimate: 75%; the middle value lies on the limit itself.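

Going by these compounds alone, no step from compound 4 to compound 1, compound 2 or compound 3 can be read in this assay, because all four compounds stand at a limit and not at a number: the limit of > 26000 nM in this assay, at which 4 of the 4 values shown sit.

The compounds shown leave open how far these four lie from one another, and whether any group at this position gives a reading inside the assay's range.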